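Para-substituted benzoate esters on a shared core

The compounds below may be only part of what the source reports. "The series", "measured", "known", "first", "only" and "open" are said of these compounds alone.

Measured compounds:
Compound 1 `CC1=CC[C@H](C(C)C)c2cc(C)c(OC(=O)c3ccc([N+](=O)[O-])cc3)cc21`, 47.5%
Compound 2 `CC1=CC[C@H](C(C)C)c2cc(C)c(OC(=O)c3ccccc3)cc21`, 37%

In a functional assay on SK-LU-1 cells (Homo sapiens) for antiproliferative activity, read by sulforhodamine B assay, with a stated time of 48 h, tested at 50 uM (on this read-out lower numbers stand for less inhibition and higher numbers for more inhibition at the one concentration tested (going by the name of the read-out)), compound 2 stands lowest of the two numbers, with compound 1 the nearer and higher one. Going by the values given here, the only step known is a number 10.5 percentage points lower from compound 1 to compound 2 (beyond the scatter), the change being hydrogen in place of nitro on an aromatic carbon. Compound 3 `CC1=CC[C@H](C(C)C)c2cc(C)c(OC(=O)c3ccc(C(F)(F)F)cc3)cc21` differs from compound 2 by trifluoromethyl in place of hydrogen on an aromatic carbon, para to a large group. The step from compound 1 to compound 2 bears on this only loosely, as both changes occur at the same aromatic carbon but with different groups entering. A modest rise is expected for compound 3, about a number 6 percentage points higher from compound 2 to compound 3 (within the scatter) in this assay, giving an estimated 43% with a range from 30% to 56%.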

Compound 3, a percentage reported as inhibition, at one concentration (the size of the read-out at that concentration, not a potency): "not active" (no number reported)
No number was reported for compound 3; no gap can be computed for the estimate.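

In this assay, going by these compounds alone, compound 3 is recorded as not active, with no number, so no step from compound 2 to compound 3 can be read. No evidence bears on this result. The compounds shown leave open how trifluoromethyl compares in size of inhibition with nitro or hydrogen on the shared core.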